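A Stereocentre Inverted on a Shared Cytotoxic Scaffold

The compounds below may be only part of what the source reports. "The series", "measured", "known", "first", "only" and "open" are said of these compounds alone.

Compound 1 `C=C(C)[C@@H]1C[C@@H](CC2(CC=C(C)C)C(=O)C(C(CC(=O)O)c3ccccc3)=C3O[C@H](C)[C@@H](C)C(=O)C3=C2O)C1(C)C`: in a functional assay on Jurkat cells (Homo sapiens) for cytotoxicity (a lower number here means a stronger inhibitor, a higher number a weaker inhibitor), compound 1 reports only a limit, > 20 ug/mL.
Compound 2 `C=C(C)CCC1(C=C(C)C)C(=O)C2=C(O)[C@H](C)[C@@H](C)OC2=C(C(CC(=O)O)c2ccccc2)C1=O`: in this assay compound 2 likewise reports only a limit, > 20 ug/mL.

Compound 2 thus stands at the edge of what this assay can resolve, as does every other value shown (the limit of > 20 ug/mL in this assay, at which 2 of the 2 values shown sit). Within the data shown here, no step between two numbered values exists, so nothing measured tells how any change shifts potency here. Compound 3 `C=C(C)CCC1(C=C(C)C)C(=O)C2=C(O)[C@H](C)[C@H](C)OC2=C(C(CC(=O)O)c2ccccc2)C1=O` differs from compound 2 only in configuration: the two compounds have the same atoms and bonds; at least one stereo element is drawn with a configuration in one of them and without one in the other: 1 of 4 stereo elements differ; a stereocentre at a saturated ring carbon is drawn R in compound 2 and S in compound 3. With the same atoms and bonds, no step beyond the usual scatter is expected; the estimated shift a step that the limit leaves unreadable from compound 2 to compound 3 is essentially none. Compound 3 is therefore expected to give about 40 ug/mL in this assay, between 15 ug/mL and 120 ug/mL, most likely again reported as a limit.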

Compound 3, half-maximal inhibitory concentration: > 20 ug/mL
Compound 3 gave a limit, no number (the forecaster's own chance of this, stated with the estimate: 85%); the middle value lies beyond the limit too.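

Among these compounds, compound 3, like compound 2, sits only at a limit, so no step between the two can be read. The compounds shown leave open whether the configuration at this saturated ring carbon affects potency in this assay.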